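The compounds below may be only part of what the source reports. "The series", "measured", "known", "first", "only" and "open" are said of these compounds alone.

Measured in a physicochemical assay for pharmacokinetics; on this read-out lower numbers stand for a shorter-lived compound and higher numbers for a longer-lived compound:
- compound 1 `O=C(NCc1ccccc1Br)N1C(=O)c2ccccc2S1(=O)=O`: > 166 h
- compound 2 `O=C(Oc1ccccc1)N1C(=O)c2ccccc2S1(=O)=O`: > 3.04 h

Both values are limits, not numbers. Compound 2 therefore stands only at its limit of > 3.04 h. Compound 3 `O=C(NCc1cccs1)N1C(=O)c2ccccc2S1(=O)=O` differs from it by ((thiophen-2-yl)methyl)amino in place of phenoxy on a carbonyl carbon, with ((thiophen-2-yl)methyl)amino in place of phenoxy on a carbonyl carbon. Among the measured compounds shown here, no measured step covers this change. Compound 1 also carries a nitrogen on that carbonyl carbon, and its limit is > 166 h. A rise in this assay beyond the scatter is expected, with an expected step that the limit leaves unreadable from compound 2 to compound 3. For compound 3 the estimated value is 100 h, with an expected range of 20 h to 400 h.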

Compound 3, half-life: > 166 h
Compound 3: only a limit was reported; the forecaster's own chance of this, stated with the estimate: 60%; middle value at least 1.6-fold (0.22 log units) from the limit.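

In this assay, among the compounds shown here, the values of compound 1, compound 2 and compound 3 are all limits, and no step to compound 3 can be read. Going by these compounds, the actual half-lives of all three stay open, as does whether ((thiophen-2-yl)methyl)amino in place of phenoxy shifts the read-out at all.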